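Shortening the prenyl-type ether chain on the cyclopropane series

The source may hold more compounds than are shown below. What is called first, only, known or untested is meant among the compounds shown, and "the series" means these compounds.

Measured compounds:
- compound 1, `O=C(NNc1nncc2ccccc12)C1CC1c1ccc(OC(F)(F)F)cc1`: 92000 nM
- compound 2, `CC(C)=CCC/C(C)=C/COc1ccc(C2CC2C(=O)NNc2nncc3ccccc23)cc1`: 24000 nM

Both numbers come from a functional assay on PC-3 cells (Homo sapiens) for inhibition, read by MTT assay, with a stated time of 72 h; a lower number here means a stronger inhibitor, a higher number a weaker inhibitor. Among the compounds with values here, compound 2 holds the lower of the two values; compound 1 sits a 3.8-fold lower number from compound 1 to compound 2 (0.58 log units; beyond the scatter) away, the only step recorded so far, and it runs from trifluoromethyl on the ring oxygen to the longer 3,7-dimethylocta-2,6-dien-1-yl chain.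

Compound 3, `CC(C)=CCOc1ccc(C2CC2C(=O)NNc2nncc3ccccc23)cc1`, is not yet measured. It differs from compound 2 as follows: hydrogen in place of 3-methylbut-2-en-1-yl on a saturated chain carbon bound to a double-bonded chain carbon. The chain on the ether oxygen is therefore cut back to the shorter 3-methylbut-2-en-1-yl, leaving compound 3 between compound 1 and compound 2 in chain length. Within the data shown here, only the single step from compound 1 to compound 2 bears on this, and compound 3 is expected to land partway back toward compound 1, so a modest rise in the number is expected, a 1.7-fold higher number from compound 2 to compound 3 (0.22 log units; within the scatter). In this assay compound 3 is thus estimated at 40000 nM, with a range from 15000 nM to 100000 nM.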

Compound 3, half-maximal inhibitory concentration: 81000 nM
Compound 3: middle estimate off by 2.0-fold (0.31 log units), on the low side; the range from low to high includes it.
By their numbers in this assay, from the lowest: compound 2; then compounds 3 and 1 (each within the scatter of the next).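

In this assay, cutting the chain on the ether oxygen from 3,7-dimethylocta-2,6-dien-1-yl back to 3-methylbut-2-en-1-yl gives a 3.4-fold higher number from compound 2 to compound 3 (0.53 log units; beyond the scatter) and so loses the gain seen with the longer chain. Set against trifluoromethyl on the same oxygen, 3-methylbut-2-en-1-yl gives a 1.1-fold lower number from compound 1 to compound 3 (0.06 log units; within the scatter) and cannot be told apart from it, so among these three compounds only the 3,7-dimethylocta-2,6-dien-1-yl chain stands apart at this position. Nothing at hand accounts for this difference.

As far as these compounds go, whether the separation depends on chain length alone or also on the double bonds remains open, and a saturated decyl chain on the same oxygen would separate the two. Also open, from the compounds shown here alone, is whether a still longer chain of the same branched type, with one more double bond, would take the number lower than compound 2 shows.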